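Swapping a Methylphenyl for a Difluorophenyl

A few compounds are considered here, and "the series" means these few. Any claim that something is new, unique, unknown or untested is made for them only; others in the source may bear on it.

Of the compounds shown here, two sharing one core have been measured in a functional assay on ME18 cells (Homo sapiens) for cytotoxicity, read by MTT assay, with a stated time of 48 h; a lower number here means a stronger inhibitor, a higher number a weaker inhibitor. Compound 1, `Fc1cc(F)cc(C(c2c[nH]c3ccccc23)c2c[nH]c3ccccc23)c1`, gives 17000000 nM in this assay. Compound 2, `COc1ccc2[nH]cc(C(c3ccc(C)cc3)c3c[nH]c4ccc(OC)cc34)c2c1`, gives 33000000 nM. These two numbers lie within the usual scatter of each other, so neither compound can be called the stronger or the weaker of the pair on this evidence.

Compound 3, `COc1ccc2[nH]cc(C(c3cc(F)cc(F)c3)c3c[nH]c4ccc(OC)cc34)c2c1`, has not yet been measured. It differs from compound 2 in a single place: 3,5-difluorophenyl in place of 4-methylphenyl on a saturated chain carbon bound to two aromatic carbons. The group that enters is the same 3,5-difluorophenyl that compound 1 carries on the same saturated chain carbon, while the rest of compound 3 matches compound 2. Going by the values given here, no step between measured compounds isolates this particular change, so its effect must be inferred from the two values at hand.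

Given that compound 1 and compound 2 sit so close together, the change is expected to produce no step beyond the scatter, or at most a small one. The step from compound 2 to compound 3 in this assay is estimated at a 1.7-fold lower number from compound 2 to compound 3 (0.22 log units; within the scatter). Compound 3 is therefore expected to give about 20000000 nM, with a plausible range from 8000000 nM to 50000000 nM.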

Compound 3, half-maximal inhibitory concentration: 28200000 nM
For compound 3 the middle estimate is 1.4-fold (0.15 log units) below the measured one, and the stated range covers the measured number.
By their numbers in this assay, from the lowest: compounds 1, 3 and 2 (each within the scatter of the next).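

In this assay, replacing 4-methylphenyl with 3,5-difluorophenyl on a saturated chain carbon bound to two aromatic carbons gives a 1.2-fold lower number from compound 2 to compound 3 (0.07 log units; within the scatter) while the rest of the molecule stays the same. Going by these compounds alone, this is the first direct reading of a change at this position, since compound 1 and compound 2 differ in more than this one group, and it shows that this particular swap, which adds one heavy atom and replaces the methyl group with two fluorines, produces no step that can be told apart from the scatter. No measurement available here explains this outcome.

From the compounds shown here alone, both compound 2 and compound 3 carry a phenyl ring with no hydrogen-bond donors or acceptors at this position, so it remains open whether an amine, a carboxylic acid, or a longer chain in that place would give a step beyond the scatter. A single pair also cannot show whether the same swap would give a similar step on a differently substituted version of the shared core.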